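Compound 4 after the cyano amide's loss of activity

The source may hold more compounds than are shown below. What is called first, only, known or untested is meant among the compounds shown, and "the series" means these compounds.

Values so far in a functional assay on HepG2 cells (Homo sapiens), read by MTT assay, with a stated time of 48 h (on this read-out higher numbers stand for weaker inhibition and lower numbers for stronger inhibition), are these
Compound 1 `CCn1c(C(=O)NCCN(C)C)ccc1C(CC)(CC)c1ccc(OCC(O)C(C)(C)C)c(C)c1` with 870 nM
Compound 2 `C#CCNC(=O)c1ccc(C(CC)(CC)c2ccc(OCC(O)C(C)(C)C)c(C)c2)n1CC` with > 50000 nM as a limit
Compound 3 `CCn1c(C(=O)N(C)CCC#N)ccc1C(CC)(CC)c1ccc(OCC(O)C(C)(C)C)c(C)c1` with > 50000 nM as a limit

Compound 3 gives > 50000 nM as a limit of the assay and not as a number. Its place is the limit of > 50000 nM in this assay, at which 2 of the 3 values shown sit, and nothing finer can be read from it. Compound 4 `CCn1c(C(=O)N(C)CC(=O)O)ccc1C(CC)(CC)c1ccc(OCC(O)C(C)(C)C)c(C)c1` arises from compound 3 by one change (carboxy in place of cyanomethyl on a saturated chain carbon bound to an amide-type nitrogen) with carboxy in place of cyanomethyl on a saturated chain carbon bound to an amide-type nitrogen.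

Going by the values given here, two measured steps bear on this, and both are large. They are an at least 57-fold higher number from compound 1 to compound 2 (1.75 log units; beyond the scatter) and an at least 57-fold higher number from compound 1 to compound 3 (1.75 log units; beyond the scatter) and each leaves the (2-(dimethylamino)ethyl)amino group of compound 1 behind. Neither compound 3 nor compound 4 carries that group. Between the two compounds without it there is only a step that the two limits leave unreadable from compound 2 to compound 3 so no swap at this end has yet given a readable size.

In this assay no recovery is therefore expected, and the expected change is a step that the limit leaves unreadable from compound 3 to compound 4 with no clear direction. For compound 4 the estimate is 60000 nM with an expected range from 25000 nM to 150000 nM and most likely only a limit will be reported.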

Compound 4, half-maximal inhibitory concentration: 17100 nM
For compound 4 the middle estimate is 3.5-fold (0.55 log units) above the measured one; measured number below the stated range.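

In this assay, going by these compounds alone, compound 4 is the first compound without the (2-(dimethylamino)ethyl)amino group of compound 1 to give a number and not a limit, so a change at this end of the molecule now has a size that can be read, if only as a minimum. Carboxy in place of cyanomethyl on a saturated chain carbon bound to an amide-type nitrogen gives an at least 2.9-fold lower number from compound 3 to compound 4 (0.46 log units; beyond the scatter), and the swap against the propargylamino amide gives an at least 2.9-fold lower number from compound 2 to compound 4 (0.46 log units; beyond the scatter). The recovery is only partial, with a 20-fold higher number from compound 1 to compound 4 (1.29 log units; beyond the scatter), while compound 2 and compound 3 stay at a limit of the assay, and the step between those two cannot be read: the limit of > 50000 nM in this assay, at which 2 of the 4 values shown sit.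

The compounds shown leave open how a methyl ester or a primary amide would read in place of carboxy on this chain, and whether a longer chain ending in a carboxylic acid would differ from compound 4. Also open, going by these compounds, is how much of the remaining gap to compound 1 goes with the methyl on the amide nitrogen, which a (2-(dimethylamino)ethyl)(methyl)amino group on the carbonyl carbon would address.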